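A larger aromatic amine in place of pyridine

The compounds below may be only part of what the source reports. "The series", "measured", "known", "first", "only" and "open" are said of these compounds alone.

Three compounds share one core and differ only in the group carried by the amine nitrogen. Compound 1 `C[C@@H](Cn1ccc(-c2ccc(C#N)c(Cl)c2)n1)NC(=O)c1ccccc1` gives 1830 nM in a functional assay on LNCaP cells (Homo sapiens) for antiproliferative activity, read by CCK-8 assay, with a stated time of 6 days; a higher number here means a weaker inhibitor, a lower number a stronger inhibitor. Compound 2 `C[C@@H](Cn1ccc(-c2ccc(C#N)c(Cl)c2)n1)NC(=O)C1CC(=O)C1` gives 3040 nM in this assay, and compound 3 `C[C@@H](Cn1ccc(-c2ccc(C#N)c(Cl)c2)n1)Nc1ccncc1` gives 2560 nM in this assay. Compound 3 stands second highest of these three numbers, and every measured step among them is small: a 1.7-fold higher number from compound 1 to compound 2 (0.22 log units; within the scatter), a 1.4-fold higher number from compound 1 to compound 3 (0.15 log units; within the scatter) and a 1.2-fold lower number from compound 2 to compound 3 (0.07 log units; within the scatter). Compound 4 `C[C@@H](Cn1ccc(-c2ccc(C#N)c(Cl)c2)n1)Nc1ncnc2nc[nH]c12` has not yet been measured. It differs from compound 3 in this way: a group of 9 heavy atoms (5 carbon, 4 nitrogen; one five-membered aromatic ring with 2 hetero atoms, one six-membered aromatic ring with 2 hetero atoms) in place of a group of 6 heavy atoms (5 carbon, 1 nitrogen; one six-membered aromatic ring with 1 hetero atom), on an amine nitrogen. Within the data shown here, none of the measured steps exchanges one aromatic amine substituent for a larger one, so they bear on the new step only in showing that every change at this place has so far stayed within the scatter. In this assay compound 4 is therefore expected to show no step beyond the scatter, the expected step being a 1.3-fold lower number from compound 3 to compound 4 (0.11 log units; within the scatter). The estimate for compound 4 is 2000 nM, with a range from 700 nM to 6000 nM.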

Compound 4, half-maximal inhibitory concentration: 960 nM
Compound 4: the middle estimate sits 2.1-fold (0.32 log units) above what was measured; the range from low to high includes it.
By their numbers in this assay, from the lowest: compounds 4, 1, 3 and 2 (each within the scatter of the next, the first and the last beyond it).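

Among these compounds, with compound 4, a change on this amine nitrogen moves the number beyond the scatter for the first time in this assay, with a 2.7-fold lower number from compound 3 to compound 4 (0.43 log units; beyond the scatter) and a 3.2-fold lower number from compound 2 to compound 4 (0.50 log units; beyond the scatter), so the group bearing a five-membered and a six-membered aromatic ring is separated from both the pyridin-4-yl and the (3-oxocyclobutyl)carbonyl groups. The benzoyl group of compound 1 is not separated from it, since a 1.9-fold lower number from compound 1 to compound 4 (0.28 log units; within the scatter) and so stays short of a clear difference. Nothing available explains the lower number of compound 4.

The compounds shown leave open whether the larger ring count, the ring nitrogens or the hydrogen-bond donor carries the step. A naphthyl group on the amine nitrogen, or a methyl group in place of the ring hydrogen on nitrogen in compound 4, would bear on this.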